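Acetyl removal on the anilide ring of compound 2

This account rests on a few compounds, and the source may have more. Where it says the series, first, only, none or still open, it means among the compounds named here.

Working notes on the series. Compound 1 `O=[N+]([O-])c1cccc(NS(=O)(=O)c2ccc3nc(-c4ccccc4)c(-c4ccccc4)nc3c2)c1` and compound 2 `CC(=O)c1cccc(NS(=O)(=O)c2ccc3nc(-c4ccccc4)c(-c4ccccc4)nc3c2)c1` share one core and differ only in the group carried on the anilide ring. In an ADME assay on the whole organism for pharmacokinetics, with Homo sapiens as the target (on this read-out higher numbers stand for higher oral bioavailability and lower numbers for lower oral bioavailability), compound 1 gives 85.6% and compound 2 gives 96.9%. For the measured compounds named here, the single measured step, a number 11.3 percentage points higher from compound 1 to compound 2 (beyond the scatter), places compound 2 at the higher of the two numbers on this read-out.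

Compound 3 `O=S(=O)(Nc1ccccc1)c1ccc2nc(-c3ccccc3)c(-c3ccccc3)nc2c1` is the next member: hydrogen in place of acetyl on an aromatic carbon. Going by the values given here, no measured step removes a group from this ring outright; the only step available, a number 11.3 percentage points higher from compound 1 to compound 2 (beyond the scatter), swaps one group for another and is modest in size. With compound 1 at 85.6% and compound 2 at 96.9%, both numbers already sit high on the scale, and nothing in the two measured compounds points to a large movement from the loss of the acetyl. The expected step in this assay is therefore none beyond the scatter, with a small decrease as the more likely side. Compound 3 is estimated at 90%, with a range from 72% to 100%. The step this estimate implies is a number 6.9 percentage points lower from compound 2 to compound 3 (within the scatter).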

Compound 3, oral bioavailability: 100%
The estimate for compound 3 lay 10 percentage points below the measured number, and the stated range covers the measured number.
By their numbers in this assay, from the lowest: compound 1; then compounds 2 and 3 (each within the scatter of the next).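

In this assay, taking the acetyl off this aromatic carbon gives a number 3.1 percentage points higher from compound 2 to compound 3 (within the scatter), so the acetyl group, which compound 2 carries and compound 3 lacks, is not needed for a high number on this read-out. Replacing nitro with hydrogen at the same carbon gives a number 14.4 percentage points higher from compound 1 to compound 3 (beyond the scatter), a modest step that, read with a number 11.3 percentage points higher from compound 1 to compound 2 (beyond the scatter), sets compound 1 apart from the other two, while compound 2 and compound 3 cannot be told apart at this position. No measurement available for these compounds bears on the reason for either step.

The compounds shown leave open whether an amine or a carboxylic acid on this aromatic carbon would stay level with compound 2 and compound 3, or would fall to the number of compound 1 or lower. Going by these compounds, all three compounds keep the shared core unchanged, so it also remains open whether the separation between the nitro compound and the other two would persist with a different group, such as a methoxy group, elsewhere on that core.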